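The source may report more compounds than this note shows. Statements on the series, on what has been measured and on what is new or still open speak of the compounds shown alone.

Measured in a functional assay on HCT-116 cells (Homo sapiens) for inhibition, read by MTT assay, with a stated time of 72 h; on this read-out higher numbers stand for weaker inhibition and lower numbers for stronger inhibition:
- Compound 1 `Nc1ncnc2c1c(-c1cnc3[nH]ccc3c1)nn2CC(=O)NO`: > 150000 nM (a limit, not a number)
- Compound 2 `Nc1nc2cc(-c3nn(CCCCCCCCCC(=O)NO)c4ncnc(N)c34)ccc2o1`: 23100 nM
- Compound 3 `Nc1ncnc2c1c(-c1cnc3[nH]ccc3c1)nn2CCCCCCCCCC(=O)NO`: 18700 nM

Going by the values given here, only two of these values are true numbers, and they lie together: a 1.2-fold lower number from compound 2 to compound 3 (0.09 log units; within the scatter). Compound 2 therefore has no measured number clearly on either side of it. The third value, from compound 1, is only a limit: the limit of > 150000 nM in this assay, at which 1 of the 3 values shown sits.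

Compound 4 `Nc1nc2cc(-c3nn(CCCCCC(=O)NO)c4ncnc(N)c34)ccc2o1` keeps the core of compound 2 but has a shorter chain, with hydroxycarbamoyl in place of 4-(hydroxycarbamoyl)butyl on a saturated chain carbon, five bonds along the chain from an aromatic nitrogen.

Among the compounds with values here, the one measured step changes a ring group on an aromatic carbon and leaves the chain alone, so it says little about chain length. The only hint comes from comparing the three compounds: compound 1, with the shortest chain, reaches only a limit, while compound 2 and compound 3, with the longest chains, give numbers. The chain of compound 4 falls between these extremes, so a modest rise in the number is expected, though the uncertainty is wide and a fall remains possible. The expected change is a 1.5-fold higher number from compound 2 to compound 4 (0.18 log units; within the scatter). For compound 4 the estimated value is 35000 nM, with an expected range of 8000 nM to 130000 nM.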

Compound 4, half-maximal inhibitory concentration: 21500 nM
Compound 4: the middle estimate sits 1.6-fold (0.21 log units) above what was measured, within the range that was stated.
By their numbers in this assay, from the lowest: compounds 3, 4 and 2 (each within the scatter of the next). At a limit, above all of these: compound 1.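

In this assay, placing hydroxycarbamoyl in place of 4-(hydroxycarbamoyl)butyl on a saturated chain carbon, five bonds along the chain from an aromatic nitrogen, gives a 1.1-fold lower number from compound 2 to compound 4 (0.03 log units; within the scatter). This is the first step shown that changes the chain itself rather than the ring group on the aromatic carbon, and it shows that removing this stretch of chain from the core of compound 2 leaves the two numbers within the scatter of each other. Between these two chain lengths, then, the read-out does not follow chain length, and the hydroxycarbamoyl end on the shorter chain of compound 4 gives a number of the same size as on the longer chain of compound 2.

As far as these compounds go, how short the chain can become on this core stays open, as does whether the hydroxycarbamoyl end matters at all, which a much shorter chain, or a carboxylic acid or an amine at the chain end, would address. Compound 1, which has a different ring group as well as a shorter chain, offers no number to settle this, only a limit: the limit of > 150000 nM in this assay, at which 1 of the 4 values shown sits.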